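Swapping the thiocarbonyl amine: from piperidine to diisopropylamine

A few compounds are considered here, and "the series" means these few. Any claim that something is new, unique, unknown or untested is made for them only; others in the source may bear on it.

Compound 1, `O=c1cc(CSC(=S)N2CCCCC2)oc2cc(Cl)ccc12`, gives 3000 nM in a functional assay on MDA-MB-435S cells (Homo sapiens) for antiproliferative activity, read by MTT assay, with a stated time of 72 h; a lower number here means a stronger inhibitor, a higher number a weaker inhibitor.
Compound 2, `O=c1cc(CSC(=S)N2CCCCC2)oc2ccccc12`, reaches only the assay limit of > 25000 nM in this assay.
Compound 3, `COc1ccc2oc(CSC(=S)N3CCCCC3)cc(=O)c2c1`, gives 1500 nM in this assay.

Among the compounds with values here, compound 2 stands at the weak end of the three: its value is a limit, not a number, and it is the one reading that sits at the limit of > 25000 nM in this assay, at which 1 of the 3 values shown sits. The two measured steps both alter the aromatic ring of the shared core: an at least 8.3-fold higher number from compound 1 to compound 2 (0.92 log units; beyond the scatter), and an at least 16-fold lower number from compound 2 to compound 3 (1.22 log units; beyond the scatter). Neither touches the amine on the thiocarbonyl carbon, so neither bears directly on the change to compound 4, `CC(C)N(C(=S)SCc1cc(=O)c2ccccc2o1)C(C)C`, which is diisopropylamino in place of piperidin-1-yl on a thiocarbonyl carbon.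

Within the data shown here, with no measured step at that position, the account has no ground for a shift beyond the scatter in either direction, and compound 2 itself is known only as a limit. The step from compound 2 to compound 4 is therefore expected to be a number no higher from compound 2 to compound 4 (the limit leaves the size open), with the result likely again a limit. Compound 4 is expected to give 25000 nM, within a range from 8000 nM to 60000 nM.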

Compound 4, half-maximal inhibitory concentration: > 40000 nM
Compound 4: no number, only a limit (the forecaster's own chance of this, stated with the estimate: 60%); middle value at least 1.6-fold (0.20 log units) from the limit.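

In this assay compound 4 gives the limit > 40000 nM and no number. Within the data shown here, compound 2 also stands only at a limit, so no step between compound 2 and compound 4 can be read. The compounds shown leave open how diisopropylamino compares with piperidin-1-yl on a thiocarbonyl carbon.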